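Para-substituent change on the anilino ring: fluoro to chloro

The source may hold more compounds than are shown below. What is called first, only, known or untested is meant among the compounds shown, and "the series" means these compounds.

Two compounds of this series have numbers in a functional assay, with a stated time of 150 min, tested at 10 ug/mL (a lower number here means a weaker effect, a higher number a stronger effect of the compound at the concentration tested), so far. Compound 1 `COC(=O)c1c(Nc2ccc(OC)cc2)sc(C(=O)c2ccc(OC)cc2)c1C` gives 5.9%, and compound 2 `COC(=O)c1c(Nc2ccc(F)cc2)sc(C(=O)c2ccc(OC)cc2)c1C` gives 14%. Within the data shown here, the single step between them, a number 8.1 percentage points higher from compound 1 to compound 2 (within the scatter), arose from fluoro in place of methoxy on an aromatic carbon and does not rise above the scatter. Compound 2 thus stands at the higher of the two numbers, though not separably from compound 1.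

Compound 3 `COC(=O)c1c(Nc2ccc(Cl)cc2)sc(C(=O)c2ccc(OC)cc2)c1C` differs from compound 2 by chloro in place of fluoro on an aromatic carbon. Among the measured compounds shown here, no measured step bears directly on this exchange; the only step in the set, from methoxy to fluoro at the same position, stayed within the scatter. A similar outcome is expected here, with the step of a number 1 percentage points higher from compound 2 to compound 3 (within the scatter) estimated to lie within the scatter. Compound 3 is therefore estimated at 15% in this assay, within a range of 4% to 30%.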

Compound 3, a percentage reported as activity, at one concentration (the size of the read-out at that concentration, not a potency): "not active" (no number reported)
For compound 3 the study gives words and no number; no gap can be computed for the estimate.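

Among these compounds, compound 3 is reported in words only as not active in this assay and carries no number, so no step from compound 2 to compound 3 can be read. The compounds shown leave open how far chloro in place of fluoro shifts this read-out. Nothing available bears on the cause of this result.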